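This account rests on a few compounds, and the source may have more. Where it says the series, first, only, none or still open, it means among the compounds named here.

In a functional assay on HepG2 cells (Homo sapiens) for antiproliferative activity, read by MTT assay, with a stated time of 24 h (a lower number here means a stronger inhibitor, a higher number a weaker inhibitor), compound 1, `C=CC(C)(C)c1cc(-c2ccc(OC)cc2)ccc1O`, gives 91000 nM. Among the two numbers measured here this is the higher one, and the nearest is compound 2, `C=CCc1ccc(OCC(=O)OCC)c(-c2ccc(OCC(=O)OCC)c(CC=C)c2)c1`, which in this assay gives 68900 nM; the gap between the two lies within the scatter, so neither can be called the weaker. Compound 3, `C=CCc1cc(-c2cccc([N+](=O)[O-])c2)ccc1OC`, in this assay reports only a limit of > 100000 nM and no number. Its value sits at the limit of > 100000 nM in this assay, at which 1 of the 3 values shown sits.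

Compound 4, `C=CCc1cc(-c2ccc(OC)cc2)ccc1O`, is not yet measured. It differs from compound 1 in one place: allyl in place of 1,1-dimethylprop-2-en-1-yl on an aromatic carbon. The change swaps one hydrocarbon chain for a shorter one on the same aromatic carbon, keeps the hydroxy group and leaves the rest of the shared core untouched. With no measured step of this kind among the compounds shown, no shift beyond the scatter is expected in either direction. The expected step is a 1.1-fold lower number from compound 1 to compound 4 (0.03 log units; within the scatter), which stays within the scatter. Compound 4 is therefore estimated at 85000 nM, with a range from 40000 nM to 180000 nM.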

Compound 4, half-maximal inhibitory concentration: > 100000 nM
Compound 4: no number, only a limit; the forecaster's own chance of this, stated with the estimate: 30%; middle value at least 1.1-fold (0.07 log units) away from the limit.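

Compound 4 reports only a limit in this assay, > 100000 nM, and no number. For the exchange of 1,1-dimethylprop-2-en-1-yl for allyl on this aromatic carbon, ortho to a hydroxy group, the data give an at least 1.0-fold higher number from compound 1 to compound 4 (0.04 log units; that floor lies within the scatter), so the step is known only as a floor and its full size cannot be read. The shorter chain thus gives no measured gain at this position, and the result adds a further compound at the limit: the limit of > 100000 nM in this assay, at which 2 of the 4 values shown sit.

The compounds shown leave open whether any other group on this aromatic carbon, such as a longer chain, an amine or a carboxylic acid, would give a number clearly below the limit. They also leave open what replacing the hydroxy group would do, as it stays in place across this step.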